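Trimming a Methoxy From the Group on the Sulfonyl Sulfur

The source may report more compounds than this note shows. Statements on the series, on what has been measured and on what is new or still open speak of the compounds shown alone.

Among the compounds with values here, compound 2 `COc1ccc(S(=O)(=O)c2cnc3cc(F)ccc3c2N2CCC(C)CC2)cc1OC` gives 83% in an assay on isolated protein for displacement of a labelled ligand from metabotropic glutamate receptor 5 (Homo sapiens), with a stated time of 60 min, tested at 1 uM (on this read-out higher numbers stand for more inhibition at the one concentration tested (going by the name of the read-out) and lower numbers for less inhibition), the higher of the two numbers so far, although compound 1 `Cc1cc(C)cc(S(=O)(=O)c2cnc3cc(F)ccc3c2N2CCC(C)CC2)c1`, with 80%, lies within the scatter of it. Compound 3 `COc1ccc(S(=O)(=O)c2cnc3cc(F)ccc3c2N2CCC(C)CC2)cc1` differs by hydrogen in place of methoxy on an aromatic carbon. Within the data shown here, only one measured step bears on this: a number 3 percentage points higher from compound 1 to compound 2 (within the scatter), a swap of the whole group on the sulfonyl sulfur that left this assay essentially unchanged. Removing a single methoxy is therefore expected to make a small step, a number 5 percentage points lower from compound 2 to compound 3 (within the scatter), if anything slightly downward. Compound 3 is estimated at 78%, within 62% to 92%.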

Compound 3, a percentage reported as inhibition, at one concentration (the size of the read-out at that concentration, not a potency): 90%
Compound 3: the middle estimate sits 12 percentage points below what was measured; measured number inside the range.
By their numbers in this assay, from the lowest: compounds 1, 2 and 3 (each within the scatter of the next).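

Replacing the methoxy with hydrogen, which turns 3,4-dimethoxyphenyl into 4-methoxyphenyl, gives a number 7 percentage points higher from compound 2 to compound 3 (within the scatter) in this assay, so this aromatic carbon accepts either group without a change beyond the scatter. Comparing the whole group on the sulfonyl sulfur gives a number 10 percentage points higher from compound 1 to compound 3 (within the scatter), so 3,5-dimethylphenyl and 4-methoxyphenyl cannot be told apart in this assay either. No measurement here explains these results. As far as these compounds go, whether an amine or a carboxylic acid on that same aromatic carbon would hold the number remains open.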